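A few compounds are considered here, and "the series" means these few. Any claim that something is new, unique, unknown or untested is made for them only; others in the source may bear on it.

Working notes on the series in a functional assay on CHO-K1 cells for antagonist activity at Orexin receptor type 2 (Homo sapiens), read by fluorescence and calcium flux, with a stated time of 30 min; a higher number here means a weaker inhibitor, a lower number a stronger inhibitor.

Three compounds share a core and have numbers. Compound 1 `Cc1ccc(-n2nccn2)c(C(=O)N2CCCO[C@H]2Cn2ncc(-c3ccc(F)cn3)n2)c1` gives 1.88 nM in this assay. Compound 2 `Cc1ccc(-n2nccn2)c(C(=O)N2CCCO[C@H]2Cn2ncn(-c3ccc(F)cn3)c2=O)c1` gives 5.4 nM. Compound 3 `Cc1ccc(-c2ncccn2)c(C(=O)N2CCCO[C@H]2Cn2ccc(-c3ccc(F)cn3)n2)c1` gives 3.18 nM; this number sits within the scatter of both compound 1 and compound 2, so no order among the three can be read from what is shown.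

Compound 4 `O=C(c1cc(F)ccc1-c1ncccn1)N1CCCO[C@H]1Cn1ccc(-c2ccc(F)cn2)n1` is not yet measured in this assay. It differs from compound 3 in one place: fluoro in place of methyl on an aromatic carbon, on the ring that carries the pyrimidin-2-yl group. Among the compounds with values here, no pair of measured compounds differs in just this way, so there is no measured step to lean on. With one small group swapped for another small group and nothing else changed, the step from compound 3 to compound 4 is expected to be no larger than the scatter, in either direction, as a 1.3-fold higher number from compound 3 to compound 4 (0.10 log units; within the scatter). Compound 4 is therefore estimated at 4 nM in this assay, with a range from 1.5 nM to 11 nM.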

Compound 4, half-maximal inhibitory concentration in the Orexin receptor type 2 assay: 4.58 nM
For compound 4 the middle estimate is 1.1-fold (0.06 log units) below the measured one; the range from low to high includes it.
By their numbers in the Orexin receptor type 2 assay, from the lowest: compounds 1, 3, 4 and 2 (each within the scatter of the next, the first and the last beyond it).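

Within the data shown here, this is the first measured step that changes one place only: in the Orexin receptor type 2 assay fluoro in place of methyl, on the ring that carries the pyrimidin-2-yl group, gives a 1.4-fold higher number from compound 3 to compound 4 (0.16 log units; within the scatter) and so leaves no readable change in potency at this position. In a physicochemical assay for lipophilicity, read by HPLC, at pH 7.4 (on this read-out higher numbers stand for higher lipophilicity and lower numbers for lower lipophilicity), compound 3 gives 2.36 and compound 4 gives 2.3. In the physicochemical assay the same swap gives a number 0.06 log units lower from compound 3 to compound 4 (within the scatter) and the two compounds also cannot be told apart there, while nothing shown offers a reason for either result.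

Open, as far as these compounds go, is how a group other than these two small ones, such as a methoxy, an amine or a carboxylic acid, would read at this position in the Orexin receptor type 2 assay. Also open, from the compounds shown here alone, is whether the swap gives a similar step on the core of compound 1, which lacks the pyrimidin-2-yl group.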